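Swapping 9-methoxynonyl for 1-hydroxynonyl on a long chain

The source may report more compounds than this note shows. Statements on the series, on what has been measured and on what is new or still open speak of the compounds shown alone.

Compound 1 `COCCCCCCCCCCCCCCC/C=C1/CC(CO)(COC(=O)C(C)(C)C)OC1=O` gives 0.138 ug/mL
Compound 2 `COCCCCCCCCCCCCCCC/C=C1\CC(CO)(COC(=O)C(C)(C)C)OC1=O` gives 0.189 ug/mL
Compound 3 `COC(=O)CCCCCCCCCCCCCC/C=C1\CC(CO)(COC(=O)C(C)(C)C)OC1=O` gives 0.856 ug/mL

All three values come from a functional assay on K562 cells (Homo sapiens) for antiproliferative activity; on this read-out higher numbers stand for weaker inhibition of growth and lower numbers for stronger inhibition of growth. Compound 2 and compound 1 count as level, since the double-bond change shows a 1.4-fold higher number from compound 1 to compound 2 (0.14 log units; within the scatter). The chain change gives a 4.5-fold higher number from compound 2 to compound 3 (0.66 log units; beyond the scatter), so compound 3 inhibits growth more weakly than compound 2 does.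

Compound 4 `CCCCCCCCC(O)CCCCCC/C=C1\CC(CO)(COC(=O)C(C)(C)C)OC1=O` keeps the shared core but alters the chain: 1-hydroxynonyl in place of 9-methoxynonyl on a saturated chain carbon, six bonds along the chain from a double-bonded chain carbon. The double-bond step says little about this change, as it leaves the chain untouched. Within the data shown here, compound 3 is the only measured case of a changed chain, so it is the best guide, though a loose one: no measured compound carries 1-hydroxynonyl. A step in the same direction, but smaller, therefore seems likely. The expected move in this assay is a 2.1-fold higher number from compound 2 to compound 4 (0.33 log units; beyond the scatter), towards weaker inhibition of growth. For compound 4 the estimate is 0.4 ug/mL, with an expected range from 0.12 ug/mL to 1.3 ug/mL.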

Compound 4, concentration for 50% growth inhibition: 7.3 ug/mL
Beside the measured number, compound 4's estimate is 18-fold (1.26 log units) below it, outside the stated range (above it).
By their numbers in this assay, from the lowest: compounds 1 and 2 (each within the scatter of the next); then compound 3; then compound 4.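

In this assay, the move to 1-hydroxynonyl gives a 39-fold higher number from compound 2 to compound 4 (1.59 log units; beyond the scatter), a far larger loss of growth inhibition than a 4.5-fold higher number from compound 2 to compound 3 (0.66 log units; beyond the scatter). Compound 3 alone had suggested that changes on this chain cost only modestly, and compound 4 shows that one such change can cost much more. Here the entering group sits six bonds along the chain from a double-bonded chain carbon and carries one hydrogen-bond donor, where 9-methoxynonyl carries none.

Nothing measured here bears on why growth inhibition falls so far. Compound 4 changes both the group and its place on the chain, so the two cannot be told apart; a 1-methoxynonyl group at this same place, or a 9-hydroxynonyl group in the place of 9-methoxynonyl, would be needed to separate them.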